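This account rests on a few compounds, and the source may have more. Where it says the series, first, only, none or still open, it means among the compounds named here.

Working notes on the series. In a functional assay on HCT-116 cells (Homo sapiens), read by MTT assay, with a stated time of 72 h (a lower number here means a stronger inhibitor, a higher number a weaker inhibitor), compound 3 `CNc1ncnc2c1c(-c1ccsc1)cn2[C@@H]1O[C@H](CO)[C@@H](O)[C@H]1O` gives > 20000 nM, which is a limit. Compound 2 `CNc1ncnc2c1c(-c1ccoc1)cn2[C@@H]1O[C@H](CO)[C@@H](O)[C@H]1O` gives > 20000 nM, also a limit. Both stand at the limit of > 20000 nM in this assay, at which 2 of the 3 values shown sit. Among the compounds with values here, the only measured step is a step that the two limits leave unreadable from compound 2 to compound 3, so it offers no size to carry forward.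

Compound 4 `CNc1ncnc2c1c(-c1cc3ccccc3o1)cn2[C@@H]1O[C@H](CO)[C@@H](O)[C@H]1O` follows from compound 3 by 1-benzofuran-2-yl in place of thiophen-3-yl on an aromatic carbon. Within the data shown here, compound 1 `COc1ncnc2c1c(-c1cc3ccccc3o1)cn2[C@@H]1O[C@H](CO)[C@@H](O)[C@H]1O` carries the same 1-benzofuran-2-yl group but differs elsewhere on the shared core, and it gives 13800 nM, the only number in this assay. A modest gain in inhibition is therefore expected, resting on compound 1 at 13800 nM. Another limit remains possible for compound 4. The expected step is an at least 1.4-fold lower number from compound 3 to compound 4 (0.15 log units; that floor lies within the scatter). Compound 4 is estimated at 14000 nM, with an expected range of 5000 nM to 30000 nM.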

Compound 4, half-maximal inhibitory concentration: > 20000 nM
Compound 4: a limit, no number; the forecaster's own chance of this, stated with the estimate: 50%; middle value at least 1.4-fold (0.15 log units) away from the limit.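

this assay compound 4 gives only a limit, not a number, so the larger 1-benzofuran-2-yl group does not bring the methylamino series to a measurable value: the limit of > 20000 nM in this assay, at which 3 of the 4 values shown sit. The steps to compound 4 from compound 2 and compound 3 cannot be read. Within the data shown here, the one readable change, methylamino in place of methoxy, gives an at least 1.4-fold higher number from compound 1 to compound 4 (0.16 log units; that floor lies within the scatter), so no real difference between these two groups is established.

As far as these compounds go, it remains open whether thiophen-3-yl, furan-3-yl and 1-benzofuran-2-yl differ at all on the methylamino core. Also open, from the compounds shown here alone, is whether a plain amino group or an ethoxy group in that place would give a clearer number.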